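From 1,3-Benzoxazol-2-yl to 1,3-Benzothiazol-2-yl

A few compounds are considered here, and "the series" means these few. Any claim that something is new, unique, unknown or untested is made for them only; others in the source may bear on it.

In a functional assay on A549 cells (Homo sapiens) for inhibition, read by MTT assay, with a stated time of 72 h (a higher number here means a weaker inhibitor, a lower number a stronger inhibitor), compound 1 `COc1ccc(-c2nnc(SCCCN3CCN(c4nc5ccccc5o4)CC3)o2)cc1` gives 93500 nM. Going by the values given here, compound 2 `O=C(NCc1nnc(SCCCN2CCN(c3nc4ccccc4o3)CC2)o1)c1ccccc1` gives 102000 nM, so the only two measured compounds lie within the scatter of each other and cannot be ranked. Compound 3 `COc1ccc(-c2nnc(SCCCN3CCN(c4nc5ccccc5s4)CC3)o2)cc1` keeps the rest of compound 1 but carries 1,3-benzothiazol-2-yl in place of 1,3-benzoxazol-2-yl on an amine nitrogen in a ring. Among the compounds with values here, the one measured step, a 1.1-fold higher number from compound 1 to compound 2 (0.04 log units; within the scatter), lies within the scatter, but it concerns benzamidomethyl in place of 4-methoxyphenyl on an aromatic carbon, a different place. Within the data shown here, no measured pair tests the exchange itself, so the evidence is thin. In this assay the expected step, a 1.2-fold lower number from compound 1 to compound 3 (0.07 log units; within the scatter), stays within the scatter, with no firm direction. Compound 3 is estimated at 80000 nM, with an expected range from 35000 nM to 170000 nM.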

Compound 3, half-maximal inhibitory concentration: 90300 nM
The estimate for compound 3 lay 1.1-fold (0.05 log units) below the measured number; measured number inside the range.
By their numbers in this assay, from the lowest: compounds 3, 1 and 2 (each within the scatter of the next).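

In this assay, the exchange on the amine nitrogen in a ring is now tested directly: 1,3-benzothiazol-2-yl in place of 1,3-benzoxazol-2-yl gives a 1.0-fold lower number from compound 1 to compound 3 (0.02 log units; within the scatter) and so compound 1 and compound 3 cannot be told apart. With the 4-methoxyphenyl group kept, one sulfur for one oxygen in the five-membered aromatic ring therefore gives no measurable separation at this position, a point the earlier step, made at a different place, could not address. No measurement offered here bears on why the two groups read alike.

On these data alone, it remains open whether the same exchange would read alike in compound 2, which carries benzamidomethyl in place of 4-methoxyphenyl. Also open, as far as these compounds go, is whether a simple phenyl or a pyridin-2-yl on that amine nitrogen, or a longer chain to the sulfur, would move the number beyond the scatter.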